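The source may report more compounds than this note shows. Statements on the series, on what has been measured and on what is new or still open speak of the compounds shown alone.

In an ADME assay on cells (Hepatocyte, Mus musculus) for cytotoxicity, read by MTT assay, with a stated time of 24 h (on this read-out higher numbers stand for lower toxicity in this test and lower numbers for higher toxicity in this test), compound 1 `Cc1ccc(-c2nn(-c3ccccc3)cc2-c2nc3ccccc3n2S(=O)(=O)c2ccccc2)cc1` gives 189000 nM and compound 2 `Cc1ccc(-c2nn(-c3ccccc3)cc2-c2nc3ccccc3n2S(=O)(=O)c2ccc(F)cc2)cc1` gives 167000 nM, so the two stand within the scatter of each other. Compound 3 `O=S(=O)(c1ccccc1)n1c(-c2cn(-c3ccccc3)nc2-c2ccc(F)cc2)nc2ccccc21` keeps the core of compound 1 and differs by fluoro in place of methyl on an aromatic carbon. For the measured compounds named here, the only measured step is a 1.1-fold lower number from compound 1 to compound 2 (0.05 log units; within the scatter), which is fluoro in place of hydrogen on an aromatic carbon and so a different swap, and on that slim evidence no step beyond the scatter is expected for compound 3. The estimated step is a 1.1-fold lower number from compound 1 to compound 3 (0.03 log units; within the scatter). Compound 3 is expected at 175000 nM, with an estimated range of 90000 nM to 330000 nM.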

Compound 3, half-maximal cytotoxic concentration: 231000 nM
Compound 3: middle estimate off by 1.3-fold (0.12 log units), on the low side, within the range that was stated.
By their numbers in this assay, from the lowest: compounds 2, 1 and 3 (each within the scatter of the next).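

For the compounds shown here, the step of a 1.2-fold higher number from compound 1 to compound 3 (0.09 log units; within the scatter) in this assay is the first reading at this position, since the earlier step lay on a different aromatic ring. It shows that, on the six-membered aromatic ring of carbon only, para to a large group, 4-methylphenyl can give way to 4-fluorophenyl with no step beyond the scatter. Nothing at hand explains this reading.

From the compounds shown here alone, whether an amine, a carboxylic acid or a longer chain at this position would also stay within the scatter remains open.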